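Bromophenyl in place of chlorobenzothiophene on the shared core

A few compounds are considered here, and "the series" means these few. Any claim that something is new, unique, unknown or untested is made for them only; others in the source may bear on it.

The account concerns two measured compounds and one still to be measured, all carrying the same core and read in a functional assay on BGC-823 cells (Homo sapiens) for inhibition, read by MTT assay, with a stated time of 72 h; on this read-out lower numbers stand for stronger inhibition and higher numbers for weaker inhibition. Compound 1, `Cc1cc(N2CC[C@@H](C)[C@@H](N(C)c3ncnc4[nH]ccc34)C2)n2nc(SCc3csc4ccc(Cl)cc34)nc2n1`, gives > 100000 nM, which is a limit of the assay and not a number. Compound 2, `CCCCCc1c(C)nc2nc(SCc3ccc(Cl)cc3)nn2c1N1CC[C@@H](C)[C@@H](N(C)c2ncnc3[nH]ccc23)C1`, differs from compound 1 in more than one place; in this assay compound 2 gives 32300 nM. Going by the values given here, no single-change step between measured compounds is available, so the only anchor for compound 1 is the limit of > 100000 nM in this assay, at which 1 of the 2 values shown sits.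

Compound 3, `Cc1cc(N2CC[C@@H](C)[C@@H](N(C)c3ncnc4[nH]ccc34)C2)n2nc(SCc3ccc(Br)cc3)nc2n1`, is the unmeasured partner of compound 1. The change from compound 1 to compound 3 is 4-bromophenyl in place of 5-chloro-1-benzothiophen-3-yl on a saturated chain carbon bound to a sulfur. Since compound 1 sits at the limit, the step cannot be sized from data; the expectation here is for a change of no more than the usual scatter, with compound 3 remaining weak. Compound 3 is therefore estimated at 100000 nM, within 30000 nM to 300000 nM, an expected step of a number no higher from compound 1 to compound 3 (the limit leaves the size open), and quite possibly again only a limit.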

Compound 3, half-maximal inhibitory concentration: 28000 nM
Estimate against measurement, compound 3: 3.6-fold (0.55 log units) above; the whole stated range lies above it.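

In this assay, 4-bromophenyl in place of 5-chloro-1-benzothiophen-3-yl on a saturated chain carbon bound to a sulfur gives an at least 3.5-fold lower number from compound 1 to compound 3 (0.55 log units; beyond the scatter), so a change at this position can move the read-out beyond the usual scatter. This also gives the series with this core a measured number at this place: compound 3 reads 28000 nM, with a single six-membered aromatic ring carrying bromine where compound 1 has a five-membered and a six-membered aromatic ring and a chlorine. The value of compound 1 is a limit of the assay and not a number, so the full size of the step stays unknown: the limit of > 100000 nM in this assay, at which 1 of the 3 values shown sits.

The compounds shown do not tell whether the step follows the bromine or the loss of the five-membered ring with its sulfur, and a plain phenyl at this place would begin to separate the two. On these data alone, how a 4-methoxyphenyl or a 4-carboxyphenyl would read here also stays open, as does whether the same step would appear on a core with other substituents.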